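From hydroxy to amino: compound 3 and compound 4

The compounds below may be only part of what the source reports. "The series", "measured", "known", "first", "only" and "open" are said of these compounds alone.

Going by the values given here, in a functional assay on K562 cells (Homo sapiens) for cytotoxicity, read by MTT assay, with a stated time of 5 days (on this read-out lower numbers stand for stronger inhibition and higher numbers for weaker inhibition), compound 3 `COc1ccc(-c2cnnn2Cc2cc(OC)c(OC)c(OC)c2)cc1O` gives 530 nM, the lowest of the numbers so far. Compound 1 `COc1ccc(Cn2nncc2-c2cc(OC)c(OC)c(OC)c2)cc1` gives 8660 nM, higher than the number for compound 3 by more than the scatter. In this assay compound 2 `COc1ccc(-c2cnnn2Cc2cc(OC)c(OC)c(OC)c2)cc1Br` is reported only as a limit, > 10000 nM.

Among the compounds with values here, the one measured step on the relevant carbon is an at least 18-fold lower number from compound 2 to compound 3 (1.27 log units; beyond the scatter), with hydroxy in place of bromo on an aromatic carbon. Its size rests on that limit, so the true gap is not known.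

Compound 4 `COc1ccc(-c2cnnn2Cc2cc(OC)c(OC)c(OC)c2)cc1N` keeps the shared core of compound 3 and changes one group: amino in place of hydroxy on an aromatic carbon. The amino group enters ortho to a methoxy group and meta to a large group, turning 3-hydroxy-4-methoxyphenyl into 3-amino-4-methoxyphenyl.

Within the data shown here, no measured step covers amino. The step to compound 3 shows only that this carbon can matter, and bromo is a poor guide to an exchange that leaves the hydrogen-bond donor and acceptor counts as they are. From the compounds shown here alone, with compound 3 at 530 nM as the anchor, no change beyond the scatter is expected in this assay, and the direction stays open. The estimated step is a 1.1-fold lower number from compound 3 to compound 4 (0.03 log units; within the scatter). Compound 4 is estimated at 500 nM, with an expected range from 130 nM to 2000 nM.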

Compound 4, half-maximal inhibitory concentration: 380 nM
Beside the measured number, compound 4's estimate is 1.3-fold (0.12 log units) above it; the measured number falls inside the stated range.
By their numbers in this assay, from the lowest: compounds 4 and 3 (each within the scatter of the next); then compound 1. At a limit, above all of these: compound 2.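

In this assay, the exchange on this carbon gives a 1.4-fold lower number from compound 3 to compound 4 (0.14 log units; within the scatter), so hydroxy and amino cannot be told apart here, and a second group now sits at this level rather than hydroxy alone. The exchange leaves the hydrogen-bond donor and acceptor counts unchanged, and for this pair the number also stays within the scatter, though one pair sets no rule. Bromo now stands apart from two groups rather than one, with an at least 26-fold lower number from compound 2 to compound 4 (1.42 log units; beyond the scatter), but compound 2 is known only as a limit, so this step is a bound and not a measured size: the limit of > 10000 nM in this assay, at which 1 of the 4 values shown sits.

The compounds shown leave open how a methylamino group, an acetamido group or a plain hydrogen on this carbon would read, and so how far the tolerance seen for hydroxy and amino extends once the group grows or is removed. Fluoro or chloro in the same place would also be needed to show whether the gap to compound 2 belongs to halogens in general or to bromo alone.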